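Fluorophenyl positional isomer on the 8-hydroxyquinoline series

The source may hold more compounds than are shown below. What is called first, only, known or untested is meant among the compounds shown, and "the series" means these compounds.

Compound 3 `Cc1ccnc(NC(c2ccc(F)cc2)c2ccc3cccnc3c2O)c1` gives 140 nM in an assay for inhibition of protein disulfide-isomerase (Homo sapiens), with a stated time of 1 h (a lower number here means a stronger inhibitor, a higher number a weaker inhibitor), the lowest of the three numbers. Compound 1 `Cc1ccnc(NC(c2ccc([N+](=O)[O-])cc2)c2ccc3cccnc3c2O)c1` gives 530 nM in this assay, and compound 2 `Cc1ccnc(NC(c2ccc(C(F)(F)F)cc2)c2ccc3cccnc3c2O)c1` gives 26500 nM. The steps of a 3.8-fold lower number from compound 1 to compound 3 (0.58 log units; beyond the scatter) and a 190-fold lower number from compound 2 to compound 3 (2.28 log units; beyond the scatter) show that what sits on this phenyl ring moves the number strongly; a 50-fold higher number from compound 1 to compound 2 (1.70 log units; beyond the scatter) is likewise large.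

Compound 4 `Cc1ccnc(NC(c2cccc(F)c2)c2ccc3cccnc3c2O)c1` differs from compound 3 by 3-fluorophenyl in place of 4-fluorophenyl on a saturated chain carbon bound to an aromatic carbon and a nitrogen on an aromatic ring. Among the compounds with values here, no measured step moves a group to a different place on the ring, so none bears on this change directly; the measured steps only say that this ring is sensitive. A modest step is therefore expected, direction uncertain, leaning weaker: compound 4 is estimated at 300 nM (range 80 nM to 1200 nM), meaning an expected 2.1-fold higher number from compound 3 to compound 4 (0.33 log units; beyond the scatter).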

Compound 4, half-maximal inhibitory concentration: 350 nM
Compound 4: middle estimate off by 1.2-fold (0.07 log units), on the low side; the measured number falls inside the stated range.
By their numbers in this assay, from the lowest: compound 3; then compounds 4 and 1 (each within the scatter of the next); then compound 2.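

Changing 4-fluorophenyl to 3-fluorophenyl gives the first read on place alone in this assay: a 2.5-fold higher number from compound 3 to compound 4 (0.40 log units; beyond the scatter), so the place of the fluorine counts, though this step is only modest. Compound 4 keeps most of the gap to the trifluoromethyl compound, with a 76-fold lower number from compound 2 to compound 4 (1.88 log units; beyond the scatter), while a 1.5-fold lower number from compound 1 to compound 4 (0.18 log units; within the scatter) leaves it not separable from the nitro compound. No measurement here accounts for the effect of moving the fluorine.

Open, from the compounds shown here alone, is whether nitro or trifluoromethyl respond to the same change of place as fluoro. Also open, going by these compounds, is how a chloro, methoxy or amine group on this phenyl ring would read.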